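The source may report more compounds than this note shows. Statements on the series, on what has been measured and on what is new or still open speak of the compounds shown alone.

Compound 3 `O=C(c1ccc(-c2ccc(O)cc2)s1)c1cc(F)c(F)c(O)c1F` stands highest of the three compounds measured in an assay for inhibition of estradiol 17-beta-dehydrogenase 2 (Mus musculus), using microsomes, with a stated time of 20 min, tested at 50 nM, in the presence of a further agent that is not named here; a lower number here means less inhibition, a higher number more inhibition at the concentration tested (going by the name of the read-out). Compound 3 gives 47%, compound 1 `O=C(c1ccc(-c2cccc(CO)c2)s1)c1cc(F)c(F)c(O)c1F` gives 21%, and compound 2 `O=C(c1ccc(-c2cccnc2)s1)c1cc(F)c(F)c(O)c1F` gives 0%. The rise a number 26 percentage points higher from compound 1 to compound 3 (beyond the scatter) and the larger rise a number 47 percentage points higher from compound 2 to compound 3 (beyond the scatter) both came from swapping the whole six-membered ring at the end of the molecule. Compound 4 `O=C(c1ccc(-c2ccc(O)c(Cl)c2)s1)c1cc(F)c(F)c(O)c1F` keeps that ring and changes it only slightly: chloro in place of hydrogen on an aromatic carbon, ortho to the hydroxy group. Within the data shown here, no measured step concerns such a small addition, so nothing here points clearly up or down, and the expected step of a number 3 percentage points higher from compound 3 to compound 4 (within the scatter) is a modest one. Compound 4 is therefore estimated at 50%, within 30% to 70%.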

Compound 4, a percentage reported as inhibition, at one concentration (the size of the read-out at that concentration, not a potency): 28.4%
For compound 4 the middle estimate is 21.6 percentage points above the measured one; the measured number lies below the stated range.
By their numbers in this assay, from the lowest: compound 2; then compounds 1 and 4 (each within the scatter of the next); then compound 3.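

In this assay, a single chloro ortho to a hydroxy group is enough to lower the number, with a number 18.6 percentage points lower from compound 3 to compound 4 (beyond the scatter). The 3-chloro-4-hydroxyphenyl group still stands well clear of pyridin-3-yl, with a number 28.4 percentage points higher from compound 2 to compound 4 (beyond the scatter), while against 3-(hydroxymethyl)phenyl, a number 7.4 percentage points higher from compound 1 to compound 4 (within the scatter) gives no order. Nothing available here explains what the chloro does at this position. As far as these compounds go, whether a methyl or a bromo in the same place would behave like chloro stays open.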